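Swapping a chloro for a fluoro anilino substituent

The source may report more compounds than this note shows. Statements on the series, on what has been measured and on what is new or still open speak of the compounds shown alone.

Compound 1 `O=C(CSc1nc(Nc2ccccc2)c2ccccc2n1)Nc1ccc([N+](=O)[O-])cc1`: > 50000 nM in a functional assay on MGC-803 cells (Homo sapiens) for inhibition, read by MTT assay, with a stated time of 72 h (on this read-out lower numbers stand for stronger inhibition and higher numbers for weaker inhibition), which is a limit of the assay rather than a number.
Compound 2 `C=CC(=O)Nc1cccc(NC(=O)CSc2nc(Nc3cccc(Cl)c3)c3ccccc3n2)c1`: 7830 nM in this assay.

Among the compounds with values here, compound 2 holds the only measured number here. Compound 1 gives only a limit, (the limit of > 50000 nM in this assay, at which 1 of the 2 values shown sits). Compound 3 `C=CC(=O)Nc1cccc(NC(=O)CSc2nc(Nc3ccc(F)cc3)c3ccccc3n2)c1` differs from compound 2 by 4-fluorophenyl in place of 3-chlorophenyl on a nitrogen on an aromatic ring. Within the data shown here, no step between measured compounds is available to judge such a swap, so no shift beyond the usual scatter is expected from it. Compound 3 is therefore estimated at 8000 nM, with a range from 3000 nM to 25000 nM. The expected step in this assay is a 1.0-fold higher number from compound 2 to compound 3 (0.01 log units; within the scatter).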

Compound 3, half-maximal inhibitory concentration: 8290 nM
Estimate against measurement, compound 3: 1.0-fold (0.02 log units) below; the range from low to high includes it.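

In this assay, within the data shown here, the step at this position reads a 1.1-fold higher number from compound 2 to compound 3 (0.02 log units; within the scatter), the first direct comparison of two substituted rings on this nitrogen. Here, 4-fluorophenyl and 3-chlorophenyl cannot be told apart, even though the halogen and its ring position differ together. No measured property shown bears on this result.

Which of those two differences matters alone remains open. So does whether a ring carrying a carboxylic acid or an amine would give a similar number.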